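This account rests on a few compounds, and the source may have more. Where it says the series, first, only, none or still open, it means among the compounds named here.

Compound 1 `Nc1cc(N)c2nc(-c3ccccc3)c(Oc3ccc(Cl)c(Cl)c3)nc2c1` was tested in a functional assay on K562 cells (Homo sapiens) for inhibition, read by sulforhodamine B assay, with a stated time of 48 h; on this read-out higher numbers stand for weaker inhibition of growth and lower numbers for stronger inhibition of growth. In this assay compound 1 gives < 100000 nM, which is a limit of the assay rather than a measured number. Two other compounds share the core of compound 1 with different groups attached: compound 2 `CCOC(=O)[C@H](CCC(=O)O)NC(=O)c1ccc(CNc2nc3cc(N)cc(N)c3nc2-c2ccccc2)cc1` and compound 3 `COc1ccc(CNc2nc3cc(N)cc(N)c3nc2-c2ccccc2)cc1OC`. In this assay compound 2 gives < 100000 nM, again only a limit. In this assay compound 3 gives < 100000 nM, also a limit. Going by the values given here, compound 1 therefore sits at the limit of < 100000 nM in this assay, at which 3 of the 3 values shown sit, and nothing among the measured compounds separates it from the other two. Compound 4 `Nc1cc(N)c2nc(-c3ccccc3)c(NCc3ccc(F)cc3)nc2c1` has not yet been measured; it differs from compound 1 by (4-fluorobenzyl)amino in place of 3,4-dichlorophenoxy on an aromatic carbon. Among the compounds with values here, no measured pair shows what such a change does in this cell growth read-out, so no direction can be argued from the data. The expected step is a step that the limit leaves unreadable from compound 1 to compound 4, with a good chance that the result is once more reported only as a limit. For compound 4 the estimated value in this assay is 30000 nM, expected to fall between 3000 nM and 100000 nM.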

Compound 4, concentration for total growth inhibition: < 100000 nM
Compound 4 ended at the assay's limit; the forecaster's own chance of this, stated with the estimate: 60%; the middle value does not contradict the limit.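

In this assay, going by these compounds alone, the values of compound 1, compound 3 and compound 4 are all limits rather than measured numbers, and no step from compound 1 or compound 3 to compound 4 can be read. The compounds shown leave open how strongly each one inhibits growth, and whether (4-fluorobenzyl)amino and 3,4-dichlorophenoxy differ at all at this place.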